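Hydroxy in place of hydrogen on compound 1

The source may report more compounds than this note shows. Statements on the series, on what has been measured and on what is new or still open speak of the compounds shown alone.

In an ADME assay on HepG2 cells (Homo sapiens) for cytotoxicity, read by resazurin assay, with a stated time of 24 h (a lower number here means that less compound is tolerated, a higher number that more compound is tolerated), compound 1 (`CCN(CC)C(=O)c1c(O)cccc1CCc1ccc2ccccc2c1`) gives > 100000 nM, which is a limit and not a number. This is the limit of > 100000 nM in this assay, at which 1 of the 2 values shown sits. Compound 2 (`CCN(CC)C(=O)c1c(CCc2ccc3ccccc3c2)cccc1OC`) gives 35800 nM. Compound 3 (`CCN(CC)C(=O)c1c(O)cc(O)cc1CCc1ccc2ccccc2c1`) has hydroxy in place of hydrogen on an aromatic carbon, para to a diethylcarbamoyl group (hydroxy in place of hydrogen on an aromatic carbon). Among the measured compounds shown here, the only measured step, an at least 2.7-fold lower number from compound 1 to compound 2 (0.44 log units; beyond the scatter), is a methyl in place of hydrogen on an oxygen on an aromatic ring, a different change that bears only loosely here. No step beyond the scatter is therefore expected in this assay. The expected step is a number no higher from compound 1 to compound 3 (the limit leaves the size open). Compound 3 is estimated at 100000 nM, with an expected range of 45000 nM to 200000 nM.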

Compound 3, half-maximal cytotoxic concentration: 36400 nM
The estimate for compound 3 lay 2.7-fold (0.44 log units) above the measured number; the measured number lies below the stated range.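

In this assay, hydroxy in place of hydrogen on the aromatic carbon para to a diethylcarbamoyl group gives an at least 2.7-fold lower number from compound 1 to compound 3 (0.43 log units; beyond the scatter), so this ring carbon is not silent, and a change away from the existing oxygen also lowers the tolerated concentration. Compound 1 gives > 100000 nM, which is a limit and not a number, so only the lower bound of this step is known.

As far as these compounds go, the full size of the step remains open. So does whether an amine or a carboxylic acid on this carbon would give a similar step.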